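Putting a Methoxy Back Where the Cyclopentyloxy Was

The compounds below may be only part of what the source reports. "The series", "measured", "known", "first", "only" and "open" are said of these compounds alone.

Measured compounds:
compound 1, `COc1ccc(C(=O)Nc2c(F)cccc2F)cc1OC1CCCC1`: 70 nM
compound 2, `COc1ccc(C(=O)Nc2ccccc2O)cc1OC1CCCC1`: 1300 nM
compound 3, `COc1ccc(C(=O)Nc2c(F)cccc2F)cc1`: 37000 nM

In an assay on isolated protein for inhibition of phosphodiesterase 4A (Sus scrofa) (a higher number here means a weaker inhibitor, a lower number a stronger inhibitor), compound 3 gives 37000 nM, the highest number of the three, and therefore the weakest inhibitor of the set. Compound 2 gives 1300 nM and compound 1 gives 70 nM, both lower.

Compound 4, `COc1ccc(C(=O)Nc2c(F)cccc2F)cc1OC`, differs from compound 3 in one place: methoxy in place of hydrogen on an aromatic carbon. The new group sits ortho to a methoxy group and meta to a large group, on the same aromatic carbon that carries the cyclopentyloxy group in compound 1.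

Among the measured compounds shown here, one measured step bears directly on this change: a 530-fold higher number from compound 1 to compound 3 (2.72 log units; beyond the scatter), the removal of the cyclopentyloxy group, which cost a great deal in this assay. The step of a 19-fold higher number from compound 1 to compound 2 (1.27 log units; beyond the scatter) concerns the other aromatic ring and is not informative here. Compound 4 restores an alkoxy group at the emptied position, but a far smaller one than cyclopentyloxy, so only part of that loss is expected to be recovered. A step in the lowering direction, clearly beyond the scatter but well short of the full amount, is expected: a 15-fold lower number from compound 3 to compound 4 (1.17 log units; beyond the scatter). The estimate for compound 4 in this assay is 2500 nM, with a range from 500 nM to 12000 nM.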

Compound 4, half-maximal inhibitory concentration: 900 nM
Estimate against measurement, compound 4: 2.8-fold (0.44 log units) above, within the range that was stated.
By their numbers in this assay, from the lowest: compound 1; then compounds 4 and 2 (each within the scatter of the next); then compound 3.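

In this assay, methoxy on this aromatic carbon, an entering group of only 2 heavy atoms, gives a 41-fold lower number from compound 3 to compound 4 (1.61 log units; beyond the scatter), which shows that much of the loss seen with hydrogen at this position is regained by a small alkoxy group and does not need a cyclopentyl ring. The alkyl group on this oxygen still matters, since methyl in place of cyclopentyl gives a 13-fold higher number from compound 1 to compound 4 (1.11 log units; beyond the scatter), so the contribution at this position divides into two separate steps, hydrogen to methoxy and methyl to cyclopentyl on the oxygen, each of them large. Nothing available explains why either step has the size it has.

The compounds shown leave open how the numbers run between methyl and cyclopentyl on this oxygen, as an ethoxy, isopropoxy or cyclobutyloxy group would show, and whether a hydroxy group at the same position would behave like hydrogen or like methoxy. They also leave open whether the step from cyclopentyloxy to methoxy would keep its size with the 2-hydroxyphenyl group of compound 2 on the amide nitrogen.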